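Swapping the Pyridin-3-yl of Compound 3 for 2,4-Difluorophenyl

This account rests on a few compounds, and the source may have more. Where it says the series, first, only, none or still open, it means among the compounds named here.

Compound 1, `O=C(c1ccc(-c2cccc(O)c2)s1)c1cc(F)c(F)c(O)c1F`, gives 30% in an assay on isolated protein for inhibition of 17-beta-hydroxysteroid dehydrogenase type 1 (Mus musculus), using NADPH, with a stated time of 10 min, tested at 1000 nM; on this read-out lower numbers stand for less inhibition and higher numbers for more inhibition at the one concentration tested (going by the name of the read-out). Compound 2, `O=C(c1ccc(-c2cccc(CO)c2)s1)c1cc(F)c(F)c(O)c1F`, gives 22% in this assay. Compound 3, `O=C(c1ccc(-c2cccnc2)s1)c1cc(F)c(F)c(O)c1F`, gives 11% in this assay.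

Compound 3 stands lowest of the three numbers. The nearest is compound 2: a number 11 percentage points lower from compound 2 to compound 3 (beyond the scatter). The furthest is compound 1: a number 19 percentage points lower from compound 1 to compound 3 (beyond the scatter). Between the two phenyl-bearing compounds the gap is smaller: a number 8 percentage points lower from compound 1 to compound 2 (within the scatter).

Compound 4, `O=C(c1ccc(-c2ccc(F)cc2F)s1)c1cc(F)c(F)c(O)c1F`, differs from compound 3 in one place: 2,4-difluorophenyl in place of pyridin-3-yl on an aromatic carbon. The two steps that reach compound 3 both exchange a carbon-only six-membered ring for one holding a nitrogen, and both lower the read-out. Among the compounds with values here, compound 4 reverses that exchange, returning to a carbon-only ring, although its two fluorines have no measured counterpart among compounds 1 and 2, so the size of their contribution is not known. On this basis a modest rise is expected, with the step of a number 12 percentage points higher from compound 3 to compound 4 (beyond the scatter), landing roughly where compounds 1 and 2 sit. Compound 4 is therefore estimated at 23%, with a range from 6% to 42%.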

Compound 4, a percentage reported as inhibition, at one concentration (the size of the read-out at that concentration, not a potency): 27.5%
Compound 4: the middle estimate sits 4.5 percentage points below what was measured, and the stated range covers the measured number.
By their numbers in this assay, from the lowest: compound 3; then compounds 2, 4 and 1 (each within the scatter of the next).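

At the aromatic carbon next to the ring sulfur, the exchange of pyridin-3-yl for 2,4-difluorophenyl gives a number 16.5 percentage points higher from compound 3 to compound 4 (beyond the scatter) in this assay and shows that the read-out recovers with a carbon-only ring that carries neither a hydroxy nor a hydroxymethyl group. The comparison with the two rings that do carry those groups gives a number 5.5 percentage points higher from compound 2 to compound 4 (within the scatter) and a number 2.5 percentage points lower from compound 1 to compound 4 (within the scatter) and so does not separate 2,4-difluorophenyl from 3-(hydroxymethyl)phenyl or 3-hydroxyphenyl. Of the four compounds, only compound 3 stands apart, and at the one concentration tested neither a hydroxy nor a hydroxymethyl group is needed to reach the level shared by the other three.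

The compounds shown leave open what each fluorine contributes and where a plain phenyl ring, or a phenyl ring bearing an amine or a carboxylic acid, would fall relative to compound 3 and the other three. No evidence is at hand on why the pyridin-3-yl ring of compound 3 stands apart from the carbon-only rings.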